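This account rests on a few compounds, and the source may have more. Where it says the series, first, only, none or still open, it means among the compounds named here.

Measured so far in a functional assay on A549 cells (Homo sapiens) for cytotoxicity; on this read-out lower numbers stand for an effect already at smaller amounts and higher numbers for an effect only at larger amounts of compound:
- compound 1 `COC1=C(C)C(=O)/C(=C(O)/C=C/c2ccccc2OC)C(=O)C1(C)C`: 2.4 ug/mL
- compound 2 `COC1=C(C)C(=O)/C(=C(O)/C=C/c2ccc(C)cc2)C(=O)C1(C)C`: 4.3 ug/mL

Going by the values given here, with only two compounds measured, compound 2 cannot be separated from the other one. Among the compounds with values here, the single measured step is a 1.8-fold higher number from compound 1 to compound 2 (0.25 log units; within the scatter), and it exchanges 2-methoxyphenyl for 4-methylphenyl.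

Compound 3 `COC1=C(C)C(=O)/C(=C(O)/C=C/c2ccccc2C)C(=O)C1(C)C` is made from compound 2 by a further change at that same place, on a double-bonded chain carbon bound to a double-bonded chain carbon: 2-methylphenyl in place of 4-methylphenyl on a double-bonded chain carbon bound to a double-bonded chain carbon. The same atoms are simply joined differently. Within the data shown here, no measured pair isolates this exact exchange, so the one step above is the only guide, and it stayed within the scatter. In this assay, no change beyond the scatter is therefore expected, and the expected step is a 1.3-fold lower number from compound 2 to compound 3 (0.11 log units; within the scatter). Compound 3 is estimated at 3.3 ug/mL, with an expected range of 1.5 ug/mL to 7 ug/mL.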

Compound 3, concentration for half-maximal effect: 4.6 ug/mL
Compound 3: the middle estimate sits 1.4-fold (0.14 log units) below what was measured; the range from low to high includes it.
By their numbers in this assay, from the lowest: compounds 1, 2 and 3 (each within the scatter of the next).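

In this assay, 2-methylphenyl in place of 4-methylphenyl gives a 1.1-fold higher number from compound 2 to compound 3 (0.03 log units; within the scatter) and so shows that, at this place on the chain, the read-out does not separate these two arrangements of the same atoms. Methyl in place of methoxy on an aromatic carbon gives a 1.9-fold higher number from compound 1 to compound 3 (0.28 log units; within the scatter) and adds a second exchange on the phenyl ring that also stays within the scatter. No measurement is available that would explain these small steps.

The three compounds leave open whether any group on this phenyl ring can move the number beyond the scatter. An amine or a carboxylic acid on the ring, or a longer chain in place of the methyl, would test this more strongly than the small groups compared so far.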